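This account rests on a few compounds, and the source may have more. Where it says the series, first, only, none or still open, it means among the compounds named here.

This account concerns a small set of chalcones that share one core. In a functional assay on HT-29 cells (Homo sapiens) for antiproliferative activity, read by MTT assay, with a stated time of 24 h (on this read-out higher numbers stand for weaker inhibition and lower numbers for stronger inhibition), compound 1 `COc1cccc(/C=C/C(=O)c2ccc(OC)c3c2OC(C)(C)C=C3)c1` reports only a limit of the assay, > 10000 nM. Compound 2 `COc1ccc(C(=O)/C=C/c2cccc([N+](=O)[O-])c2)c2c1C=CC(C)(C)O2` gives 4260 nM in this assay. Going by the values given here, the single step between measured compounds that differ in one place is an at least 2.3-fold lower number from compound 1 to compound 2 (0.37 log units; beyond the scatter), and the value of compound 1 sits at the limit of > 10000 nM in this assay, at which 2 of the 3 values shown sit. Compound 3 `COc1ccc(C(=O)/C=C/c2ccc(C(F)(F)F)cc2)c2c1C=CC(C)(C)O2` likewise reports only a limit of the assay in this assay, > 10000 nM. Compound 3 therefore stands with compound 1 at the limit rather than with compound 2. The unmeasured compound 4 `COc1ccc(C(=O)/C=C/c2ccc(O)cc2)c2c1C=CC(C)(C)O2` differs from compound 3 by hydroxy in place of trifluoromethyl on an aromatic carbon. Among the compounds with values here, no measured step covers this change: the one step available, an at least 2.3-fold lower number from compound 1 to compound 2 (0.37 log units; beyond the scatter), concerns a nitro entering for a methoxy, and the trifluoromethyl of compound 3 appears in no other pair. What the numbers do show is that the methoxy of compound 1 and the trifluoromethyl of compound 3 both sit at the limit, while only the nitro of compound 2 yields a number. Hydroxy in place of trifluoromethyl is therefore expected to move the value little, and the step is estimated as an at least 1.2-fold lower number from compound 3 to compound 4 (0.09 log units; that floor lies within the scatter). Compound 4 is expected to give about 8000 nM in this assay, within the range 3000 nM to 20000 nM, with a fair chance of another limit.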

Compound 4, half-maximal inhibitory concentration: > 10000 nM
Compound 4 ended at the assay's limit (the forecaster's own chance of this, stated with the estimate: 55%); middle value at least 1.2-fold (0.09 log units) away from the limit.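

With hydroxy in place of trifluoromethyl on an aromatic carbon para to a large group, compound 4 also reports only a limit of the assay in this assay, so a group with one hydrogen-bond donor and one hydrogen-bond acceptor and a group with neither end at the same mark at this position: the limit of > 10000 nM in this assay, at which 3 of the 4 values shown sit.

The steps from compound 3 and from compound 1 to compound 4 cannot be read, as both ends of each are limits. The one step that can be read is an at least 2.3-fold higher number from compound 2 to compound 4 (0.37 log units; beyond the scatter), with 4-hydroxyphenyl in place of 3-nitrophenyl, which leaves the 3-nitrophenyl of compound 2 as the only group among those shown that yields a number rather than a limit.

Going by these compounds, how compound 1, compound 3 and compound 4 rank against one another stays open, and so does whether hydroxy and trifluoromethyl differ at all in this read-out. The compounds shown also do not tell whether a nitro, an amine or a carboxylic acid on this same aromatic carbon, para to a large group, would bring the value down to a number.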